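A few compounds are considered here, and "the series" means these few. Any claim that something is new, unique, unknown or untested is made for them only; others in the source may bear on it.

Compound 1 `O=C(/C=C/c1ccccc1)Nc1ccc2c(c1)COC2=O`: in a functional assay on cells (T-cell, Mus musculus) for inhibition (on this read-out lower numbers stand for stronger inhibition and higher numbers for weaker inhibition), compound 1 gives 7240 nM.
Compound 2 `COc1ccccc1/C=C/C(=O)Nc1ccc2c(c1)COC2=O`: in this assay compound 2 gives 39 nM.
Compound 3 `Cc1cccc(NC(=O)Nc2ccc3c(c2)COC3=O)c1`: in this assay compound 3 gives 2260 nM.

Among these three numbers compound 3 stands second highest. Its nearest neighbour is compound 1, whose number is higher by a margin beyond the scatter; compound 2 lies far below it, also beyond the scatter. Among the compounds with values here, the one measured step that can be put against this series, a 190-fold lower number from compound 1 to compound 2 (2.27 log units; beyond the scatter), concerns a methoxy set on an aromatic carbon of the cinnamamide pair and says nothing about what happens when the aryl group on the urea nitrogen of compound 3 is exchanged.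

Compound 4 `O=C(Nc1ccc(Cl)cc1)Nc1ccc2c(c1)COC2=O` differs from compound 3 in exactly that way: 4-chlorophenyl in place of 3-methylphenyl on an amide-type nitrogen. The change sits on an amide-type nitrogen whose other neighbours are: carbonyl carbon. Within the data shown here, no measured step bears on it, so there is no ground for expecting a move in either direction in this assay, and the expectation is of no step beyond the scatter, with a wide range to reflect the lack of guidance. Compound 4 is therefore estimated at 2500 nM, between 600 nM and 10000 nM, which means an expected step of a 1.1-fold higher number from compound 3 to compound 4 (0.04 log units; within the scatter).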

Compound 4, half-maximal inhibitory concentration: 2450 nM
Compound 4: the middle estimate sits 1.0-fold (0.01 log units) above what was measured, within the range that was stated.
By their numbers in this assay, from the lowest: compound 2; then compounds 3 and 4 (each within the scatter of the next); then compound 1.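

In this assay, within the data shown here, setting 4-chlorophenyl in place of 3-methylphenyl on the amide-type nitrogen gives a 1.1-fold higher number from compound 3 to compound 4 (0.04 log units; within the scatter), the first reading of any change at this place on the urea. It shows that these two aryl groups, which have the same count of heavy atoms and both carry a single substituent on a six-membered aromatic ring, cannot be told apart in this read-out, so this particular exchange leaves the number where it was within the scatter. Because the chlorine and the methyl also carry different numbers in their group names, this one pair cannot separate a change of substituent from a change of where it stands on the ring, and no measurement on hand offers a reason for the result.

The compounds shown leave open whether the methoxy-bearing aryl group of compound 2, which belongs to the cinnamamide pair with a 190-fold lower number from compound 1 to compound 2 (2.27 log units; beyond the scatter), would move the number on the urea as well. They also leave open how the number would respond to an amine or a carboxylic acid on this aryl group, or to a cyclohexyl group or a longer alkyl chain in its place on the amide-type nitrogen.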